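This account rests on a few compounds, and the source may have more. Where it says the series, first, only, none or still open, it means among the compounds named here.

Compound 1 `O=C(CSc1snnc1-c1ccc(Br)cc1Br)Nc1ccccn1` gives 42400 nM in an ADME assay on MT4 cells (Homo sapiens) for cytotoxicity, read by MTT assay, with a stated time of 5 days; a higher number here means that more compound is tolerated, a lower number that less compound is tolerated.
Compound 2 `COC(=O)c1ccsc1NC(=O)CSc1snnc1-c1ccc(Br)cc1Br` gives > 227000 nM, which is a limit of the assay.
Compound 3 `Cc1ccc(NC(=O)CSc2snnc2-c2ccc(Br)cc2Br)c(Br)c1` gives > 216000 nM, likewise a limit of the assay.

Compound 3 therefore stands at the top of what is shown, at the limit of > 216000 nM in this assay, at which 1 of the 3 values shown sits, and only a limit is known for it, as for compound 2 at the limit of > 227000 nM in this assay, at which 1 of the 3 values shown sits. Compound 4 `Cc1ccc(NC(=O)CSc2snnc2-c2ccc(Br)cc2Br)cc1` differs from it by hydrogen in place of bromo on an aromatic carbon. The measured steps, an at least 5.3-fold higher number from compound 1 to compound 2 (0.72 log units; beyond the scatter) and an at least 5.0-fold higher number from compound 1 to compound 3 (0.70 log units; beyond the scatter), exchange the whole group on the amide-type nitrogen, and a step that the two limits leave unreadable from compound 2 to compound 3; none removes a bromo alone, so they bear on this change only loosely. The step is expected to stay within the scatter, an at least 1.0-fold lower number from compound 3 to compound 4 (0.03 log units; that floor lies within the scatter), with compound 4 estimated at 200000 nM, ranging from 60000 nM to 300000 nM.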

Compound 4, half-maximal cytotoxic concentration: 24000 nM
For compound 4 the middle estimate is 8.3-fold (0.92 log units) above the measured one; measured number outside the range, below it.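

For the compounds shown here, removing the bromo gives an at least 9.0-fold lower number from compound 3 to compound 4 (0.95 log units; beyond the scatter) in this assay and is the first change here of a single atom. With the bromo gone, the 4-methylphenyl group gives an at least 9.4-fold lower number from compound 2 to compound 4 (0.97 log units; beyond the scatter) and a 1.8-fold lower number from compound 1 to compound 4 (0.25 log units; within the scatter) on an amide-type nitrogen, so the higher number of compound 3 over compound 1 does not carry over to compound 4. Compound 3 is known only as a limit: the limit of > 216000 nM in this assay, at which 1 of the 4 values shown sits.

As far as these compounds go, whether a chloro, methoxy or ethyl group on that aromatic carbon would act like bromo stays open. From the compounds shown here alone, the full size of the step also stays open, as compound 3 has no exact value.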